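Ethylamino to dimethylamino: what to expect of compound 4

The source may report more compounds than this note shows. Statements on the series, on what has been measured and on what is new or still open speak of the compounds shown alone.

compound 1 `C=C(c1ccc(OC)cc1NC(=O)CO)c1ccc(OC)c2c1C=CC(C)(C)O2`: 280 nM
compound 2 `C=C(c1ccc(OC)cc1NC(=O)CN)c1ccc(OC)c2c1C=CC(C)(C)O2`: 400 nM
compound 3 `C=C(c1ccc(OC)cc1NC(=O)CNCC)c1ccc(OC)c2c1C=CC(C)(C)O2`: 2010 nM

In a functional assay on A2780 cells (Homo sapiens) for antiproliferative activity, read by MTT assay, with a stated time of 48 h (a higher number here means a weaker inhibitor, a lower number a stronger inhibitor), compound 3 has the highest number of the three, 2010 nM. The measured steps show a 5.0-fold higher number from compound 2 to compound 3 (0.70 log units; beyond the scatter) and a 7.2-fold higher number from compound 1 to compound 3 (0.86 log units; beyond the scatter), whereas a 1.4-fold higher number from compound 1 to compound 2 (0.15 log units; within the scatter). Compound 4 `C=C(c1ccc(OC)cc1NC(=O)CN(C)C)c1ccc(OC)c2c1C=CC(C)(C)O2` differs from compound 3 by dimethylamino in place of ethylamino on a saturated chain carbon bound to a carbonyl carbon. For the measured compounds named here, the closest evidence is the step with ethyl in place of hydrogen on an amine nitrogen, a 5.0-fold higher number from compound 2 to compound 3 (0.70 log units; beyond the scatter), but no measured compound carries dimethylamino. No step beyond the scatter is therefore expected in this assay. The expected change is a 1.3-fold lower number from compound 3 to compound 4 (0.13 log units; within the scatter). Compound 4 is estimated at 1500 nM, within a range of 550 nM to 4000 nM.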

Compound 4, half-maximal inhibitory concentration: 670 nM
Compound 4: the middle estimate sits 2.2-fold (0.35 log units) above what was measured; measured number inside the range.
By their numbers in this assay, from the lowest: compounds 1, 2 and 4 (each within the scatter of the next, the first and the last beyond it); then compound 3.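

In this assay, the same atoms joined as dimethylamino instead of ethylamino at this position give a clear change (a 3.0-fold lower number from compound 3 to compound 4 (0.48 log units; beyond the scatter)), so the heavy-atom count of the group does not alone set the number here. Dimethylamino stays within the scatter of amino (a 1.7-fold higher number from compound 2 to compound 4 (0.22 log units; within the scatter)) but remains apart from hydroxy (a 2.4-fold higher number from compound 1 to compound 4 (0.38 log units; beyond the scatter)). Nothing available explains the gap between ethylamino and dimethylamino. On these data alone, it remains open where methylamino would fall, and whether diethylamino or a ring amine such as morpholine would track ethylamino or dimethylamino.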